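Methyl for Chloro on the Sulfanyl Aryl of Compound 1

A few compounds are considered here, and "the series" means these few. Any claim that something is new, unique, unknown or untested is made for them only; others in the source may bear on it.

The measured compounds and their values are these. Compound 1 `O=C(/C(=C\c1ccc(Cl)cc1)Sc1ccc(Cl)cc1)c1ccc(Cl)cc1` gives 1000 nM in a functional assay on DU-145 cells (Homo sapiens) for inhibition, read by trypan blue exclusion, with a stated time of 96 h; on this read-out lower numbers stand for stronger inhibition of growth and higher numbers for weaker inhibition of growth. Compound 2 `Cc1ccc(S(=O)(=O)/C(=C/c2ccc(F)cc2F)C(=O)c2ccc(Br)cc2)cc1` reaches only a limit of this assay, > 100000 nM, and no number. Compound 3 `COc1ccc(/C=C(\C(=O)c2ccc(Br)cc2)S(=O)(=O)c2ccc(Br)cc2)c(OC)c1` gives 8000 nM in this assay.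

Among the two numbers shown, compound 1 stands lowest; compound 3 gives the higher number, and the gap between compound 1 and compound 3 lies beyond the usual scatter of this assay. Compound 2 contributes only a limit, so no ordering against it can be drawn.

The step of interest leads from compound 1 to compound 4 `Cc1ccc(S/C(=C/c2ccc(Cl)cc2)C(=O)c2ccc(Cl)cc2)cc1`, which has not yet been measured in this assay. The change is methyl in place of chloro on an aromatic carbon, which read one bond further out turns a (4-chlorophenyl)sulfanyl into a (4-methylphenyl)sulfanyl. For the measured compounds named here, no step between measured compounds shows the effect of this change, so any expectation rests on the structural change alone. Since chloro and methyl are both single heavy atoms without donors, acceptors or charge, the expected step is small, in no clear direction, and not beyond the scatter. The expected step of a 1.5-fold higher number from compound 1 to compound 4 (0.18 log units; within the scatter) reflects this. Compound 4 is therefore estimated to give about 1500 nM in this assay, with a range from 500 nM to 5000 nM.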

Compound 4, concentration for 50% growth inhibition: 10000 nM
The estimate for compound 4 lay 6.7-fold (0.82 log units) below the measured number, outside the stated range (above it).
By their numbers in this assay, from the lowest: compound 1; then compounds 3 and 4 (each within the scatter of the next). At a limit, above all of these: compound 2.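

In this assay, the exchange of chloro for methyl on the aromatic carbon of the (4-chlorophenyl)sulfanyl group gives a 10-fold higher number from compound 1 to compound 4 (1.00 log units; beyond the scatter), so this position responds clearly to the change even though both groups have one heavy atom and neither has a hydrogen-bond donor, hydrogen-bond acceptor or net charge. For the compounds shown here, the earlier compounds offered no step between compounds differing in one place, and this step is the first direct reading of any single change on this core. Nothing shown here accounts for the size of the step.

The compounds shown leave open whether the weaker growth inhibition is specific to methyl or would follow other replacements of chloro at this position, such as fluoro, methoxy, an amine or a carboxylic acid. They also leave open whether the same exchange of chloro for methyl on either of the other two chlorophenyl rings of compound 1 would give a step of similar size.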